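A Methyl Removed from the Aromatic Ring of Compound 1

The compounds below may be only part of what the source reports. "The series", "measured", "known", "first", "only" and "open" are said of these compounds alone.

Compound 1 `CC(=O)Nc1cc(C)c(CCS(=O)(=O)N2CCC3(CC2)N=C(C2CCCCC2)NC3=O)c(C)c1` was examined in an ADME assay on microsomes from liver (Homo sapiens) for metabolic stability, read by LC-MS, using NADPH, with a stated time of 30 min, tested at 1 uM (a higher number here means faster removal of the compound, a lower number slower removal), where compound 1 gives 39 uL/min. Its only measured companion, compound 2 `Cc1cc(N(C)C(N)=O)cc(C)c1CCS(=O)(=O)N1CCC2(CC1)N=C(C1CCCCC1)NC2=O`, gives 23 uL/min in this assay, so compound 1 stands at the upper end of the two numbers shown, although the step of a 1.7-fold lower number from compound 1 to compound 2 (0.23 log units; within the scatter) lies within the scatter and does not separate the two. Compound 3 `CC(=O)Nc1ccc(CCS(=O)(=O)N2CCC3(CC2)N=C(C2CCCCC2)NC3=O)c(C)c1` differs from compound 1 in a single place: hydrogen in place of methyl on an aromatic carbon. For the measured compounds named here, the one recorded step, a 1.7-fold lower number from compound 1 to compound 2 (0.23 log units; within the scatter), concerns a different group and gives no direct guidance on a methyl replaced by hydrogen; it also stayed within the scatter. Nothing in the data points to a movement beyond the scatter in this assay in either direction. Compound 3 is therefore expected to give about 35 uL/min in this assay, with a range from 18 uL/min to 70 uL/min. The expected step is a 1.1-fold lower number from compound 1 to compound 3 (0.05 log units; within the scatter).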

Compound 3, intrinsic clearance in a liver preparation (reported as CLH), per the amount of preparation that the assay uses in the Homo sapiens assay: 46 uL/min
Compound 3: the middle estimate sits 1.3-fold (0.12 log units) below what was measured; the range from low to high includes it.
By their numbers in the Homo sapiens assay, from the lowest: compounds 2, 1 and 3 (each within the scatter of the next).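

In the Homo sapiens assay, hydrogen in place of methyl on this aromatic carbon, ortho to a large group, gives a 1.2-fold higher number from compound 1 to compound 3 (0.07 log units; within the scatter), so that assay does not separate the two compounds. In a physicochemical assay for solubility, read by HPLC, in simulated intestinal fluid, tested at 1 mM (a higher number here means a more soluble compound, a lower number a less soluble compound), however, compound 1 gives 38 ug/mL and compound 3 gives 400 ug/mL. This is the first step shown that lies beyond the scatter, and it ties the loss of this one methyl to a large gain in solubility, which the earlier compounds could not show: the measured solubility of compound 1, 38 ug/mL, and of compound 3, 400 ug/mL, an 11-fold higher number (1.02 log units; beyond the scatter)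

The compounds shown leave open whether a fluorine atom or a methoxy group on this carbon would keep the solubility of compound 3. They also leave open whether removing the remaining methyl group would add to the step or whether the step would carry over to the carbamoyl(methyl)amino series.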